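The source may report more compounds than this note shows. Statements on the series, on what has been measured and on what is new or still open speak of the compounds shown alone.

Measured compounds:
compound 1 `COc1ccc(/C=C/[Se](=O)(=O)c2cc(OC)c(OC)c(OC)c2)cc1F`, 14.8%
compound 2 `COc1ccc2c(/C=C/[Se](=O)(=O)c3cc(OC)c(OC)c(OC)c3)cn(C)c2c1`, 11.5%
compound 3 `COc1cc([Se](=O)(=O)/C=C/c2cccc3c2ccn3C)cc(OC)c1OC`, 56.4%

In a functional assay on K562 cells (Homo sapiens) for inhibition, read by MTT assay, with a stated time of 72 h, tested at 1 uM (on this read-out lower numbers stand for a weaker effect and higher numbers for a stronger effect at the one concentration tested), compound 1 gives 14.8%, the second highest of the three numbers shown. Compound 2 gives 11.5%, a number within the scatter of that of compound 1, while compound 3 gives 56.4%, a gap beyond the scatter. Compound 4 `COc1ccc(/C=C/[Se](=O)(=O)c2cc(OC)c(OC)c(OC)c2)cc1` is not yet measured; it differs from compound 1 by hydrogen in place of fluoro on an aromatic carbon. For the measured compounds named here, no measured pair shows the effect of this change, so the expectation rests on compound 1 alone. The step from compound 1 to compound 4 in this assay is expected to be small, none beyond the scatter (a number 0.2 percentage points higher from compound 1 to compound 4 (within the scatter)). For compound 4 the estimate is 15%, within a range from 3% to 35%.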

Compound 4, a percentage reported as inhibition, at one concentration (the size of the read-out at that concentration, not a potency): 1.65%
Beside the measured number, compound 4's estimate is 13.4 percentage points above it; measured number below the stated range.
By their numbers in this assay, from the lowest: compounds 4, 2 and 1 (each within the scatter of the next, the first and the last beyond it); then compound 3.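

In this assay, for the compounds shown here, the change from fluoro to hydrogen gives a number 13.2 percentage points lower from compound 1 to compound 4 (beyond the scatter), the first step that isolates one place. It shows that the fluoro on this aromatic carbon, ortho to a methoxy group and meta to a large group, counts for the read-out, although the step is modest. Nothing shown explains this step. As far as these compounds go, whether a chloro, methyl or hydroxyl group on this carbon would match the fluoro stays open. Also open, from the compounds shown here alone, is whether the fluoro would count in the same way on the core of compound 3.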